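Selenium-Bearing Chain Replaces Aminoethoxy on a Shared Core

This account rests on a few compounds, and the source may have more. Where it says the series, first, only, none or still open, it means among the compounds named here.

Measured compounds:
Compound 1, `Cc1nc(N(C)c2ccc([Se]C#N)c(Cl)c2)c2ccccc2n1`: 12 nM
Compound 2, `COc1ccc(N(C)c2nc(C)nc3ccccc23)cc1OCCN`: 343 nM
Compound 3, `COc1ccc(N(C)c2nc(C)nc3ccccc23)cc1C(=O)NCC[Se]C#N`: 179 nM

All three were tested in a functional assay on HepG2 cells (Homo sapiens) for inhibition, read by MTT assay, with a stated time of 48 h; on this read-out higher numbers stand for weaker inhibition and lower numbers for stronger inhibition. Among the three numbers, compound 2 stands highest. Its nearest neighbour is compound 3, whose number lies within the scatter of it, so the two cannot be ordered. The gap from compound 2 down to compound 1 is beyond the scatter, so compound 1 is clearly the stronger inhibitor of that pair.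

Compound 4, `COc1ccc(N(C)c2nc(C)nc3ccccc23)cc1C(=O)OCCC[Se]C#N`, has not yet been measured. It differs from compound 2 in one place: a group of 9 heavy atoms (5 carbon, 1 nitrogen, 2 oxygen, 1 selenium; no ring) in place of a group of 4 heavy atoms (2 carbon, 1 nitrogen, 1 oxygen; no ring), on an aromatic carbon. For the measured compounds named here, the only measured step that bears on this is a 1.9-fold lower number from compound 2 to compound 3 (0.28 log units; within the scatter), in which a related chain, also containing selenium, replaced the same 2-aminoethoxy group on the same aromatic carbon of the shared core. That step stayed within the scatter. Compound 4 carries a longer chain of the same kind, so a similar outcome is expected: a small move toward lower numbers, not beyond the scatter.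

Compound 4 is therefore estimated to give 170 nM in this assay, a step of a 2.0-fold lower number from compound 2 to compound 4 (0.30 log units; within the scatter), with an expected range from 60 nM to 450 nM.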

Compound 4, half-maximal inhibitory concentration: 340 nM
For compound 4 the middle estimate is 2.0-fold (0.30 log units) below the measured one, and the stated range covers the measured number.
By their numbers in this assay, from the lowest: compound 1; then compounds 3, 4 and 2 (each within the scatter of the next).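

In this assay, replacing the 2-aminoethoxy group with a chain of 9 heavy atoms gives a 1.0-fold lower number from compound 2 to compound 4 (0.00 log units; within the scatter), so this aromatic carbon, ortho to a methoxy group, takes a much larger group with 0 hydrogen-bond donors and no readable change in the number. Changing what sits on the carbonyl carbon gives a 1.9-fold higher number from compound 3 to compound 4 (0.28 log units; within the scatter), so this change of link and length cannot be told apart from ordinary assay variation either. All three compounds that differ at this aromatic carbon now lie within the scatter of one another, and no supporting measurement is available to explain that flat picture.

As far as these compounds go, it remains open whether a carboxylic acid, a simple amine or a much longer chain on this aromatic carbon would move the number beyond the scatter. Compound 1, at 12 nM, differs from the other compounds in more than one place, so its number cannot be assigned to any single structural change.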